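Methyl in place of chloro: compound 1 to compound 4

The source may report more compounds than this note shows. Statements on the series, on what has been measured and on what is new or still open speak of the compounds shown alone.

- compound 1 `CNC(=O)c1cc(C(=O)N[C@H]2CC[C@H](O)CC2)c([C@@H](C)c2cccc(Cl)c2)o1`: >= 179 ug/mL (a limit)
- compound 2 `CC(=O)Nc1c(F)cc(C(=O)N[C@H]2CC[C@H](O)CC2)cc1O[C@@H](C)c1ccccc1`: >= 159 ug/mL (a limit)
- compound 3 `CNC(=O)c1cc(C(=O)N[C@H]2CC[C@H](O)CC2)n([C@@H](C)c2cccc(C(F)(F)F)c2)n1`: 7 ug/mL

The series is read in a physicochemical assay for solubility, measured as kinetic solubility; a lower number here means a less soluble compound, a higher number a more soluble compound. Compound 1 gives >= 179 ug/mL, which is a limit and not a number. Compound 2 gives >= 159 ug/mL, which is also a limit. For the measured compounds named here, compound 3 gives 7 ug/mL, the only exact reading in the set. Compound 1 therefore has no exact reading and rests on (the limit of >= 179 ug/mL in this assay, at which 1 of the 3 values shown sits).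

Compound 4 `CNC(=O)c1cc(C(=O)N[C@H]2CC[C@H](O)CC2)c([C@@H](C)c2cccc(C)c2)o1` has no reading yet in this assay. It keeps the core of compound 1 and carries methyl in place of chloro on an aromatic carbon, meta to a large group: methyl in place of chloro on an aromatic carbon. Cut one bond further out, the change reads 3-chlorophenyl to 3-methylphenyl. Going by the values given here, no two measured compounds differ in one place, so the data give no direct reading of this change.

The expectation is no step beyond the scatter, in either direction. Compound 1 at >= 179 ug/mL anchors this expectation, and that value is a limit. The expected at least 1.1-fold lower number from compound 1 to compound 4 (0.04 log units; that floor lies within the scatter) is small, and a reading that is again only a limit is quite possible. For compound 4 the estimated value is 160 ug/mL, with an expected range from 70 ug/mL to 210 ug/mL.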

Compound 4, solubility: >= 172 ug/mL
Compound 4: only a limit was reported; the forecaster's own chance of this, stated with the estimate: 55%; middle value at least 1.0-fold (0.03 log units) away from the limit.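

In this assay compound 4 gives >= 172 ug/mL, which is a limit. Compound 1 gives >= 179 ug/mL, which is also a limit. With only limits on both sides, no step can be read between compound 1 and compound 4. The compounds shown leave open whether methyl in place of chloro on an aromatic carbon shifts the reading in this assay at all.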